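Swapping a Phenyl for tert-Butyl on the Shared Core

The compounds below may be only part of what the source reports. "The series", "measured", "known", "first", "only" and "open" are said of these compounds alone.

Of the compounds shown here, two have been measured so far. Compound 1 `O=S(=O)(NCCNCc1cccc2ccccc12)c1cc(C(F)(F)F)cc(C(F)(F)F)c1` and compound 2 `O=S(=O)(NCCNCc1ccc(-c2ccccc2)cc1)c1cc(C(F)(F)F)cc(C(F)(F)F)c1` share a core and differ in the aromatic group attached to it. In a functional assay on HPAC cells (Homo sapiens) for inhibition, read by MTT assay, with a stated time of 72 h (a higher number here means a weaker inhibitor of growth, a lower number a stronger inhibitor of growth), compound 1 gives 18000 nM, while compound 2 gives 2800 nM. Compound 2 thus stands as the lower of the two numbers, and its gap to compound 1 is beyond the usual scatter, so compound 2 is the stronger inhibitor of growth of the pair. For the measured compounds named here, no step between compounds that differ in one place is available; compound 1 and compound 2 differ in more than one place.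

Compound 3 `CC(C)(C)c1ccc(CNCCNS(=O)(=O)c2cc(C(F)(F)F)cc(C(F)(F)F)c2)cc1` is not yet measured. Compared with compound 2 it carries tert-butyl in place of phenyl on an aromatic carbon. Nothing in the measured pair speaks directly to this exchange, so the expectation rests on compound 2 alone. With no measured guide for this change, the step of a 1.4-fold higher number from compound 2 to compound 3 (0.15 log units; within the scatter) is estimated to be small, within or just beyond the scatter, and more likely upward than downward. Compound 3 is therefore expected to give about 4000 nM in this assay, with a range from 1500 nM to 12000 nM.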

Compound 3, concentration for 50% growth inhibition: 14000 nM
Compound 3: middle estimate off by 3.5-fold (0.54 log units), on the low side; measured number outside the range, above it.
By their numbers in this assay, from the lowest: compound 2; then compounds 3 and 1 (each within the scatter of the next).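

At this place, on an aromatic carbon and para to a large group, the phenyl of compound 2 cannot be exchanged for tert-butyl without a loss: in this assay, the change gives a 5.0-fold higher number from compound 2 to compound 3 (0.70 log units; beyond the scatter) and so moves the number clearly upward. The earlier pair could not show this, as its two members differ in more than one place, whereas here only the outer group changes, from six heavy atoms with a ring to four heavy atoms with no ring. The second step, a 1.3-fold lower number from compound 1 to compound 3 (0.11 log units; within the scatter), with 4-(tert-butyl)phenyl in place of naphthalen-1-yl on a saturated chain carbon bound to an amine nitrogen, leaves compound 1 and compound 3 level, so compound 2 alone stands apart among the three.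

Ring and size change together in this one exchange, so the data cannot say which of them matters, and a cyclohexyl group or a pyridyl ring at the same place would be needed to separate them. No measurement at hand bears on why the numbers fall as they do.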